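From a formylfuran to a formylthiophene on the shared core

The source may hold more compounds than are shown below. What is called first, only, known or untested is meant among the compounds shown, and "the series" means these compounds.

Compound 1 `O=Cc1ccc(-c2cncc(Cl)c2N2CCC3(CCNC3=O)CC2)o1` stands second highest of the three numbers in a functional assay on MV4-11 cells (Homo sapiens) for inhibition, read by resazurin assay, with a stated time of 72 h (a higher number here means a weaker inhibitor of growth, a lower number a stronger inhibitor of growth), where compound 1 gives 5190 nM. Compound 2 `CC(=O)c1ccc(-c2cncc(Cl)c2N2CCC3(CCNC3=O)CC2)s1` gives 1440 nM, and compound 3 `O=Cc1sccc1-c1cncc(Cl)c1N1CCC2(CCNC2=O)CC1` gives 28700 nM. Compound 4 `O=Cc1cc(-c2cncc(Cl)c2N2CCC3(CCNC3=O)CC2)cs1` differs from compound 1 by 5-formylthiophen-3-yl in place of 5-formylfuran-2-yl on an aromatic carbon. Going by the values given here, two measured steps bear on this change: a 3.6-fold lower number from compound 1 to compound 2 (0.56 log units; beyond the scatter), with a thiophene carrying an acetyl group, while a 5.5-fold higher number from compound 1 to compound 3 (0.74 log units; beyond the scatter), with the formyl group at another place on a thiophene. Compound 4 keeps the formyl group of compound 1 but sits on a thiophene at a new attachment point, so the measured steps point both ways, and a 20-fold higher number from compound 2 to compound 3 (1.30 log units; beyond the scatter) shows how wide that spread is. Compound 4 is therefore expected to give 6000 nM (range 2000 nM to 20000 nM), an expected step of a 1.2-fold higher number from compound 1 to compound 4 (0.06 log units; within the scatter).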

Compound 4, concentration for 50% growth inhibition: 730 nM
Beside the measured number, compound 4's estimate is 8.2-fold (0.91 log units) above it; measured number below the stated range.
By their numbers in this assay, from the lowest: compounds 4 and 2 (each within the scatter of the next); then compound 1; then compound 3.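

In this assay, 5-formylthiophen-3-yl gives a 7.1-fold lower number from compound 1 to compound 4 (0.85 log units; beyond the scatter), so a formyl-bearing thiophene at this position need not carry the acetyl group of compound 2 to reach that compound's range: a 2.0-fold lower number from compound 2 to compound 4 (0.30 log units; within the scatter). Where the formyl group sits on the thiophene weighs heavily, with a 39-fold lower number from compound 3 to compound 4 (1.59 log units; beyond the scatter) for two groups that differ only in that respect. Nothing available accounts for these differences.

The compounds shown leave open whether the formyl group itself is required. An amine or a carboxylic acid in its place on the same thiophene does not appear among them.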